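The compounds below may be only part of what the source reports. "The series", "measured", "known", "first", "only" and "open" are said of these compounds alone.

Compound 1 `O=C(CCCOc1no[n+]([O-])c1S(=O)(=O)c1ccccc1)NO`, compound 2 `O=C(CCCCOc1no[n+]([O-])c1S(=O)(=O)c1ccccc1)NO` and compound 3 `O=C(CCCCCCOc1no[n+]([O-])c1S(=O)(=O)c1ccccc1)NO` share one core and differ in the length of the chain ending in hydroxycarbamoyl. In a functional assay on U-937 cells (Homo sapiens) for inhibition, read by MTT assay, with a stated time of 48 h (on this read-out lower numbers stand for stronger inhibition and higher numbers for weaker inhibition), compound 1 gives 3300 nM, compound 2 gives 2910 nM and compound 3 gives 9930 nM. Compound 3 therefore has the highest number of the three and is the weakest inhibitor of this small set.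

Compound 4 `O=C(CCCCCCCOc1no[n+]([O-])c1S(=O)(=O)c1ccccc1)NO` lengthens the chain again: (hydroxycarbamoyl)methyl in place of hydroxycarbamoyl on a saturated chain carbon, six bonds along the chain from an oxygen on an aromatic ring. In words, this places (hydroxycarbamoyl)methyl in place of hydroxycarbamoyl on a saturated chain carbon, six bonds along the chain from an oxygen on an aromatic ring.

For the measured compounds named here, the closest precedent is the same replacement made three bonds along the chain, which gave a 1.1-fold lower number from compound 1 to compound 2 (0.05 log units; within the scatter). Larger extensions gave a 3.4-fold higher number from compound 2 to compound 3 (0.53 log units; beyond the scatter) and a 3.0-fold higher number from compound 1 to compound 3 (0.48 log units; beyond the scatter). Longer is thus not always weaker, as compound 2 shows, but the longest measured chain, in compound 3 at 9930 nM, is the weakest. No chain as long as that of compound 4 has been measured yet.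

In this assay a small rise is therefore expected, one that may not clear the scatter. The expected change is a 1.5-fold higher number from compound 3 to compound 4 (0.18 log units; within the scatter). For compound 4 the estimate is 15000 nM, with an expected range of 6500 nM to 35000 nM.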

Compound 4, half-maximal inhibitory concentration: 9300 nM
The estimate for compound 4 lay 1.6-fold (0.21 log units) above the measured number; measured number inside the range.
By their numbers in this assay, from the lowest: compounds 2 and 1 (each within the scatter of the next); then compounds 4 and 3 (each within the scatter of the next).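

In this assay, placing (hydroxycarbamoyl)methyl in place of hydroxycarbamoyl, six bonds along the chain from an oxygen on an aromatic ring, leaves the number essentially unchanged, with a 1.1-fold lower number from compound 3 to compound 4 (0.03 log units; within the scatter), so the weaker level seen with compound 3 does not worsen further at this chain length. Compound 4 also stands clearly above both shorter chains, with a 3.2-fold higher number from compound 2 to compound 4 (0.50 log units; beyond the scatter) and a 2.8-fold higher number from compound 1 to compound 4 (0.45 log units; beyond the scatter), and the four compounds therefore fall into a shorter pair and a longer pair, not a steady climb with length; the gap between the pairs is much the same whichever compounds are compared: the same change on two cores in this assay, a 3.0-fold higher number (0.48 log units; beyond the scatter) from compound 1 to compound 3 and a 3.2-fold higher number (0.50 log units; beyond the scatter) from compound 2 to compound 4, 1.1-fold (0.03 log units) apart, within the scatter of two such steps A small extension makes as little difference within the longer pair as within the shorter pair: the same change on two cores in this assay, a 1.1-fold lower number (0.05 log units; within the scatter) from compound 1 to compound 2 and a 1.1-fold lower number (0.03 log units; within the scatter) from compound 3 to compound 4, 1.1-fold (0.03 log units) apart, within the scatter of two such steps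

A still longer chain could stay at this level or move away from it, and a chain of intermediate length could show where between compound 2 and compound 3 the rise begins. As far as these compounds go, it also remains open how a carboxylic acid in place of hydroxycarbamoyl at the chain end would read in this assay.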